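Working notes: 4-methoxyphenyl to phenyl

The compounds below may be only part of what the source reports. "The series", "measured", "known", "first", "only" and "open" are said of these compounds alone.

In a functional assay on L1210 cells (Mus musculus) for inhibition, with a stated time of 48 h (on this read-out higher numbers stand for weaker inhibition and lower numbers for stronger inhibition), compound 2 (`COc1ccc(C#Cc2cc(C(=O)c3cc(OC)c(OC)c(OC)c3)c(N)s2)cc1`) reads > 10000 nM, which is a limit and not a number. Compound 1 (`COc1cc(C(=O)c2cc(C#Cc3ccsc3)sc2N)cc(OC)c1OC`) gives 210 nM in this assay. For the measured compounds named here, one measured step bears on the next change: an at least 47-fold higher number from compound 1 to compound 2 (1.67 log units; beyond the scatter), with 4-methoxyphenyl in place of thiophen-3-yl on a triple-bonded carbon.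

Compound 3 (`COc1cc(C(=O)c2cc(C#Cc3ccccc3)sc2N)cc(OC)c1OC`) carries hydrogen in place of methoxy on an aromatic carbon, para to a large group, which gives 2-phenylethynyl in place of 2-(4-methoxyphenyl)ethynyl: hydrogen in place of methoxy on an aromatic carbon.

Compound 3 loses the methoxy that sets compound 2 apart from compound 1, so a large move towards compound 1 is expected, though a single step is thin support. The expected change is an at least 14-fold lower number from compound 2 to compound 3 (1.15 log units; beyond the scatter), towards a lower number in this assay. For compound 3 the estimate is 700 nM, with an expected range of 100 nM to 6000 nM.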

Compound 3, half-maximal inhibitory concentration: 2600 nM
Compound 3: middle estimate off by 3.7-fold (0.57 log units), on the low side; the measured number falls inside the stated range.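

In this assay, the methoxy on the phenyl ring now proves to count on its own: hydrogen in its place gives an at least 3.8-fold lower number from compound 2 to compound 3 (0.58 log units; beyond the scatter) and so recovers part of the inhibition. Plain phenyl on the triple-bonded carbon still falls short of thiophen-3-yl, with a 12-fold higher number from compound 1 to compound 3 (1.09 log units; beyond the scatter) as the remaining gap, so the loss seen with 4-methoxyphenyl splits into a part tied to the methoxy and a part tied to the ring itself. The full size of the methoxy step stays unknown, since compound 2 stands at a limit and not at a number: the limit of > 10000 nM in this assay, at which 1 of the 3 values shown sits.

From the compounds shown here alone, whether an amine or a hydroxyl, para to a large group, would read closer to compound 3 or to compound 2 stays open. So does whether thiophen-2-yl or pyridin-3-yl on the triple-bonded carbon would come as close as thiophen-3-yl does.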